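The source may report more compounds than this note shows. Statements on the series, on what has been measured and on what is new or still open speak of the compounds shown alone.

For the measured compounds named here, compound 1 `CCC(Nc1cc(C)ncn1)c1ccc(Oc2ccc(F)cc2)cc1` and compound 2 `CCc1ncnc(NC(CC)c2ccc(Oc3ccc(F)cc3)cc2)c1Br` are the two measured members. In an ADME assay on HEK-293T cells (Homo sapiens) for cytotoxicity, with a stated time of 48 h (on this read-out higher numbers stand for lower toxicity in this test and lower numbers for higher toxicity in this test), compound 1 gives > 10000 nM, which is a limit of the assay and not a number. In this assay compound 2 gives > 10000 nM, again a limit of the assay rather than a number. Going by the values given here, the only recorded step, a step that the two limits leave unreadable from compound 1 to compound 2, is accordingly not readable, and the limit of > 10000 nM in this assay, at which 2 of the 2 values shown sit, is where both measured values sit. Compound 3 `CCc1nc(C)nc(NC(CC)c2ccc(Oc3ccc(F)cc3)cc2)c1Br` differs from compound 2 by methyl in place of hydrogen on an aromatic carbon. Among the compounds with values here, no measured step bears on this particular change, and the single step on record gives no size, so no shift beyond the scatter in this assay is expected in either direction. Compound 3 is expected to sit at 15000 nM, within 5000 nM to 50000 nM, most probably again reported only as a limit. The expected step that the limit leaves unreadable from compound 2 to compound 3 is estimated as essentially nil.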

Compound 3, half-maximal cytotoxic concentration: > 10000 nM
Compound 3: no number, only a limit; the forecaster's own chance of this, stated with the estimate: 85%; the middle value lies beyond the limit too.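

In this assay compound 3 gives > 10000 nM, a limit of the assay and not a number. The step between compound 2 and compound 3 therefore cannot be read. The compounds shown leave open whether any of these changes shifts cytotoxicity, and how far each compound lies from that limit.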